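Carboxymethyl on a core that shows only limits

The source may hold more compounds than are shown below. What is called first, only, known or untested is meant among the compounds shown, and "the series" means these compounds.

Compound 1 `C[C@H]1N=C2C[C@H]3C[C@H](C3(C)C)[C@@]2(C)OC1=O` stands only as a limit in an ADME assay on McCoy cells (Mus musculus) for antiproliferative activity, read by sulforhodamine B assay, with a stated time of 48 h; on this read-out lower numbers stand for stronger inhibition and higher numbers for weaker inhibition: compound 1 gives > 1800000 nM, a limit of the assay rather than a number. Its mirror image, compound 3 `C[C@@H]1N=C2C[C@@H]3C[C@@H](C3(C)C)[C@]2(C)OC1=O`, is likewise only a limit; compound 3 gives > 2000000 nM. The step that the two limits leave unreadable from compound 1 to compound 3 cannot be read because the limit of > 1800000 nM in this assay, at which 1 of the 3 values shown sits, and the limit of > 2000000 nM in this assay, at which 1 of the 3 values shown sits, cap both values, although the fact that compounds 1 and 3 differ only in the configuration as drawn shows the pair differs in configuration alone. Compound 2 `CC(C)(C)OC(=O)NCCCC[C@H]1N=C2C[C@H]3C[C@H](C3(C)C)[C@@]2(C)OC1=O`, which carries a longer chain on the shared core, is also only a limit; compound 2 gives > 1300000 nM, as the limit of > 1300000 nM in this assay, at which 1 of the 3 values shown sits, records. Compound 4 `CC1(C)[C@H]2CC3=N[C@H](CCC(=O)O)C(=O)O[C@]3(C)[C@@H]1C2` differs from compound 1 by carboxymethyl in place of hydrogen on a saturated chain carbon bound to a saturated ring carbon. Among the compounds with values here, every measured value stands at a limit, so no step has a readable size, and none points in any direction. Compound 4 is therefore expected to sit at a limit as well, and the expected step that the limit leaves unreadable from compound 1 to compound 4 is none beyond the scatter. The estimate for compound 4 in this assay is 2000000 nM, between 500000 nM and 6000000 nM.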

Compound 4, half-maximal inhibitory concentration: > 1200000 nM
Compound 4 was reported as a limit; the forecaster's own chance of this, stated with the estimate: 85%; the middle value does not contradict the limit.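

In this assay compound 4 gives > 1200000 nM as a limit and not a number. Within the data shown here, compound 1 also stands only at a limit, so no step from compound 1 to compound 4 can be read. The compounds shown leave open whether in this assay any change on the shared core gives a readable value.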